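Hydroxy in place of methoxy on a shared pyrazole series

The source may report more compounds than this note shows. Statements on the series, on what has been measured and on what is new or still open speak of the compounds shown alone.

The compounds share one core, seen in compound 1 `COc1cc(C)cc(-c2c(-c3ccnc(-c4ccc(C(C)=O)cc4)c3)cnn2CC#N)c1`, compound 2 `Cc1cc(O)cc(-c2nn(CC#N)cc2-c2ccnc(-c3ccc(Oc4ccccc4)cc3)c2)c1` and compound 3 `COc1cc(C)cc(-c2nn(CC#N)cc2-c2ccnc(-c3ccc(N(C)C)cc3)c2)c1`. In a functional assay on MDA-MB-435 cells (Homo sapiens) for inhibition, read by sulforhodamine B assay, with a stated time of 48 h (a higher number here means that more compound is tolerated, a lower number that less compound is tolerated), compound 1 reaches only the limit of > 100000 nM. Compound 2 gives 60600 nM in this assay. Compound 3, the compound from which the step starts, also stops at the limit of > 100000 nM in this assay, so no number is known for it, only a bound at which two of the three values sit (the limit of > 100000 nM in this assay, at which 2 of the 3 values shown sit).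

Compound 4 `Cc1cc(O)cc(-c2nn(CC#N)cc2-c2ccnc(-c3ccc(N(C)C)cc3)c2)c1` differs from compound 3 in one place: hydrogen in place of methyl on an oxygen on an aromatic ring, methoxy to hydroxy, 3-methoxy-5-methylphenyl to 3-hydroxy-5-methylphenyl. Within the data shown here, no measured pair shows this change directly; compound 2 carries the hydroxy group but on a different partner, so it does not fix the step.

With compound 3 only at a limit, the step from compound 3 to compound 4 is expected to be small, a number no higher from compound 3 to compound 4 (the limit leaves the size open), with no direction beyond the scatter. Compound 4 is therefore estimated at 100000 nM in this assay, between 35000 nM and 300000 nM.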

Compound 4, concentration lethal to 50% of the cells: > 100000 nM
Compound 4 was reported as a limit; the forecaster's own chance of this, stated with the estimate: 55%; the middle value lies on the limit itself.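

In this assay compound 4 also stops at a limit, > 100000 nM, so methoxy to hydroxy on this ring gives a step that cannot be read against compound 3. Among these compounds, with the hydroxy group held in place, dimethylamino in place of phenoxy on an aromatic carbon gives an at least 1.6-fold higher number from compound 2 to compound 4 (0.21 log units; that floor lies within the scatter), the first step that can be read at all, and only as a floor. The limit now holds most of the values: the limit of > 100000 nM in this assay, at which 3 of the 4 values shown sit.

From the compounds shown here alone, whether hydroxy and methoxy differ at this position stays open, for compound 3 and compound 4 both give only limits. Also open, going by these compounds, is how an amine or a carboxylic acid in place of the hydroxy group, or a longer chain on that oxygen, would read in this assay.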